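Hydroxy for vinyl on a xanthine side chain

A few compounds are considered here, and "the series" means these few. Any claim that something is new, unique, unknown or untested is made for them only; others in the source may bear on it.

Of the compounds shown here, two have been measured in a functional assay (trachea) with Cavia porcellus as the target; on this read-out lower numbers stand for an effect already at smaller amounts and higher numbers for an effect only at larger amounts of compound. Compound 1 `C=CCn1c(=O)c2[nH]cnc2n(CCC)c1=O` gives 1600 nM. Compound 2 `C=CCCn1cnc2c1c(=O)n(C)c(=O)n2CCC` gives 16800 nM, the higher of the two numbers, and the gap to compound 1 lies beyond the usual scatter of the measurement, so compound 2 is the weaker of the pair. Compound 3 `CCCn1c(=O)n(C)c(=O)c2c1ncn2CCO` has not yet been measured in this assay. It differs from compound 2 in one place: hydroxy in place of vinyl on a saturated chain carbon, two bonds along the chain from an aromatic nitrogen. Going by the values given here, no pair of measured compounds differing in a single place is available, so the size of this step cannot be read from the data. The step from compound 2 to compound 3 is expected to be small, around a 1.2-fold higher number from compound 2 to compound 3 (0.08 log units; within the scatter), with no clear direction beyond the scatter. For compound 3 the expected value is therefore 20000 nM, within a range from 6000 nM to 60000 nM.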

Compound 3, half-maximal effective concentration: 31800 nM
Estimate against measurement, compound 3: 1.6-fold (0.20 log units) below, and the stated range covers the measured number.
By their numbers in this assay, from the lowest: compound 1; then compounds 2 and 3 (each within the scatter of the next).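

In this assay, going by these compounds alone, the first single-place step at this position is a 1.9-fold higher number from compound 2 to compound 3 (0.28 log units; within the scatter), so hydroxy in place of vinyl, on a saturated chain carbon two bonds along the chain from an aromatic nitrogen, gives no difference that this read-out can separate. The swap from but-3-en-1-yl to 2-hydroxyethyl removes a double bond and adds a hydrogen-bond donor and acceptor, yet the two compounds remain within the scatter of each other. The data offer no measured explanation for this result.

Going by these compounds, it remains open whether an amine, a carboxylic acid or a longer chain at this place would also stay within the scatter of compound 2. Also open, on these data alone, is whether hydroxy in place of vinyl would give a similar step on the allyl group of compound 1.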